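From a Sulfonamide Chain to a Methylsulfone

The compounds below may be only part of what the source reports. "The series", "measured", "known", "first", "only" and "open" are said of these compounds alone.

Compound 1 `CN(C)S(=O)(=O)c1cncc(C#Cc2cc(Cl)ccc2OCC(=O)O)c1` gives 37 nM in an assay on CHO cells for displacement of a labelled ligand from prostaglandin D2 receptor 2 (Homo sapiens), read by scintillation counting; on this read-out higher numbers stand for weaker inhibition and lower numbers for stronger inhibition.
Compound 2 `COCCNS(=O)(=O)c1ccc(C)c(C#Cc2cc(Cl)ccc2OCC(=O)O)c1` gives 3.6 nM in this assay.
Compound 3 `CCCCCCc1ccncc1C#Cc1cc(Cl)ccc1OCC(=O)O` gives 43 nM in this assay.

Among these three, compound 2 has the lowest number, and so the strongest inhibition: compound 1 and compound 3 both sit clearly higher, each by a gap that lies beyond the usual scatter. Compound 1 and compound 3 differ from compound 2 in more than one place, so their values show only where they land, not what any single change does.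

Compound 4 `Cc1ccc(S(C)(=O)=O)cc1C#Cc1cc(Cl)ccc1OCC(=O)O` is not yet measured. It keeps the whole shared core of compound 2 and changes only the group on the sulfonyl sulfur: methyl in place of (2-methoxyethyl)amino on a sulfonyl sulfur. Going by the values given here, nothing among the measured compounds isolates this change, so no measured step can be borrowed for it.

What remains is the structural change itself: a chain with a hydrogen-bond donor and an acceptor is replaced by a single carbon. The expectation is a modest weakening, a step from compound 2 to compound 4 of a 2.8-fold higher number from compound 2 to compound 4 (0.44 log units; beyond the scatter) in this assay, likely at the edge of the scatter rather than far beyond it. Compound 4 is therefore estimated at 10 nM, within a range from 3 nM to 40 nM.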

Compound 4, inhibition constant: 5 nM
Compound 4: middle estimate off by 2.0-fold (0.30 log units), on the high side, and the stated range covers the measured number.
By their numbers in this assay, from the lowest: compounds 2 and 4 (each within the scatter of the next); then compounds 1 and 3 (each within the scatter of the next).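

In this assay, methyl in place of (2-methoxyethyl)amino on a sulfonyl sulfur gives a 1.4-fold higher number from compound 2 to compound 4 (0.14 log units; within the scatter), so this large change in the group leaves the two compounds indistinguishable on this read-out. For this pair, the (2-methoxyethyl)amino chain, with its hydrogen-bond donor and acceptor, is therefore not required to keep the number in the range of compound 2, since a lone methyl does as well in its place. Nothing measured here explains why the number holds when so much of the group is removed.

The compounds shown leave open whether other small groups on the sulfonyl sulfur, such as an ethyl or a plain amino group, would also stay level with compound 2 and compound 4, or whether a larger group, such as a phenyl ring, would shift the number. They also leave open whether the same exchange would be as quiet on a different core, as this single pair gives one example of it and compound 1 and compound 3 differ from it in more than one place.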